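Thiosemicarbazone series: aryl swap on the hydrazone carbon

This account rests on a few compounds, and the source may have more. Where it says the series, first, only, none or still open, it means among the compounds named here.

Measured in a functional assay on NCI/ADR cells (Homo sapiens) for cytotoxicity, read by sulforhodamine B assay; on this read-out higher numbers stand for weaker inhibition of growth and lower numbers for stronger inhibition of growth:
compound 1 `CC1=CC[C@@H]([C@@](C)(O)CCCC(C)(C)NC=S)CC1` gives 16700 nM
compound 2 `CC1=CC[C@@H]([C@@](C)(O)CCCC(C)(C)NC(=S)NN)CC1` gives 760 nM
compound 3 `COc1ccc(/C=N\NC(=S)NC(C)(C)CCC[C@](C)(O)[C@@H]2CC=C(C)CC2)cc1` gives 6730 nM

Compound 3 holds the second highest of the three numbers; its nearest neighbour is compound 1 and its furthest is compound 2. The measured steps are a 22-fold lower number from compound 1 to compound 2 (1.34 log units; beyond the scatter) and an 8.9-fold higher number from compound 2 to compound 3 (0.95 log units; beyond the scatter). Compound 4 `CC1=CC[C@@H]([C@@](C)(O)CCCC(C)(C)NC(=S)N/N=C\c2ccccc2[N+](=O)[O-])CC1` differs from compound 3 by 2-nitrophenyl in place of 4-methoxyphenyl on a carbon with a double bond to nitrogen. Among the measured compounds shown here, no measured step alters the aryl group, so neither step bears directly on this change; both only show that what sits on the hydrazine nitrogen matters. For compound 4 a step of a 1.1-fold lower number from compound 3 to compound 4 (0.05 log units; within the scatter) is expected, not beyond the scatter. Compound 4 is therefore estimated at 6000 nM, within a range from 2000 nM to 20000 nM.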

Compound 4, concentration for 50% growth inhibition: 20400 nM
Beside the measured number, compound 4's estimate is 3.4-fold (0.53 log units) below it; measured number outside the range, above it.
By their numbers in this assay, from the lowest: compound 2; then compound 3; then compounds 1 and 4 (each within the scatter of the next).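

In this assay, the aryl group on a carbon with a double bond to nitrogen can itself shift the number: 2-nitrophenyl in place of 4-methoxyphenyl gives a 3.0-fold higher number from compound 3 to compound 4 (0.48 log units; beyond the scatter). The earlier steps shown here showed only that what sits on the hydrazine nitrogen matters; this one shows that the identity of the aryl group also counts, here towards weaker inhibition of growth. Nothing available explains this shift.

On these data alone, whether 4-nitrophenyl or 2-methoxyphenyl would track compound 3 or compound 4 stays open. So does the outcome with a pyridine ring at this place.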